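Swapping Methoxy for Fluoro Across Two Related Cores

The compounds below may be only part of what the source reports. "The series", "measured", "known", "first", "only" and "open" are said of these compounds alone.

The measured compounds, with their values in a physicochemical assay for solubility, with a stated time of 18 h, at pH 7.4; on this read-out lower numbers stand for lower solubility and higher numbers for higher solubility:
compound 1, `COc1ccc(-c2ccc3c(NCCCNCc4cccc(OC)c4O)ccnc3c2)cc1`, gives 32000 nM;
compound 2, `COc1cccc(CNCCCNc2ccnc3cc(-c4ccc(F)cc4)ccc23)c1O`, gives 32000 nM;
compound 3, `COc1ccc(Oc2ccc3c(NCCCNCc4cc(F)ccc4OC)ccnc3c2)cc1`, gives 14500 nM.

Compound 1 and compound 2 share a core and differ by one change, (fluoro in place of methoxy on an aromatic carbon). That step, no change at the digits printed from compound 1 to compound 2 (within the scatter), left the read-out of this assay as it was. Compound 3 carries a different core; the difference between the two cores is not broken down here. Its value sits lowest of the three, and its gap to both compound 1 and compound 2 is beyond the usual scatter.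

Compound 4, `COc1ccc(F)cc1CNCCCNc1ccnc2cc(Oc3ccc(F)cc3)ccc12`, has not yet been measured in this assay. It differs from compound 3 by fluoro in place of methoxy on an aromatic carbon. The place of this change reads the same as for the step from compound 1 to compound 2, so it is the same change, applied on the other core.

Because the step of no change at the digits printed from compound 1 to compound 2 (within the scatter) was within the scatter, the step of a 1.0-fold lower number from compound 3 to compound 4 (0.02 log units; within the scatter) is expected to be small as well. Compound 4 is therefore estimated at 14000 nM in this assay, within a range of 6000 nM to 32000 nM.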

Compound 4, solubility: 14500 nM
Compound 4: middle estimate off by 1.0-fold (0.02 log units), on the low side; the range from low to high includes it.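

In this assay, putting fluoro in place of methoxy gave no change at the digits printed from compound 3 to compound 4 (within the scatter) and, on the other core, no change at the digits printed from compound 1 to compound 2 (within the scatter) as well, so a 4-methoxyphenoxy going to a 4-fluorophenoxy behaved like a 4-methoxyphenyl going to a 4-fluorophenyl. This shows that, in these two pairs, the swap carried from one core to the other without moving the read-out beyond the usual scatter, but two pairs cannot show that it would do so on every core in the series or at any other place on the molecule. Nothing given here explains why the read-out held steady in both pairs.

From the compounds shown here alone, whether a different group in the same place, such as an amine or a carboxylic acid, would shift the read-out remains open. Going by these compounds, it also remains open whether a third core, or a longer chain, would leave this swap just as silent.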